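The source may hold more compounds than are shown below. What is called first, only, known or untested is meant among the compounds shown, and "the series" means these compounds.

Among the compounds with values here, in a functional assay on A2780 cells (Homo sapiens) for antiproliferative activity, read by MTT assay, with a stated time of 3 days (on this read-out higher numbers stand for weaker inhibition and lower numbers for stronger inhibition), compound 3 `CC/C=C\COC1(c2ccc(Cl)cc2)SC=C(C)n2c1noc2=O` is the only member of this small set for which a number rather than a limit is reported, at 55000 nM. For compound 1 `CCCCCOC1(c2ccc(Cl)cc2)SC=C(C)n2c1noc2=O` the read-out is a limit of the assay, > 100000 nM. For compound 2 `CCCCCCCCCCCCCCCOC1(c2ccc(Cl)cc2)SC=C(C)n2c1noc2=O` the read-out is likewise a limit, > 100000 nM. Compound 4 `CCCCOC1(c2ccc(Cl)cc2)SC=C(C)n2c1noc2=O` differs from compound 3 by propyl in place of but-1-en-1-yl on a saturated chain carbon bound to an oxygen on a saturated carbon. Within the data shown here, two measured steps touch this region: a step that the two limits leave unreadable from compound 1 to compound 2, which gives no reading, and an at least 1.8-fold lower number from compound 1 to compound 3 (0.25 log units; that floor lies within the scatter). Because an at least 1.8-fold lower number from compound 1 to compound 3 (0.25 log units; that floor lies within the scatter) reaches only to the edge of the scatter, and compound 4 gives up both that carbon and the double bond, the step of a 1.8-fold higher number from compound 3 to compound 4 (0.26 log units; within the scatter) is expected to run back toward (the limit of > 100000 nM in this assay, at which 2 of the 3 values shown sit). Compound 4 is therefore estimated at 100000 nM, between 40000 nM and 300000 nM.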

Compound 4, half-maximal inhibitory concentration: 89000 nM
Estimate against measurement, compound 4: 1.1-fold (0.05 log units) above, within the range that was stated.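

In this assay, replacing the pentyl chain of the earlier saturated ether with butyl gives an at least 1.1-fold lower number from compound 1 to compound 4 (0.05 log units; that floor lies within the scatter), and the longer chain gives an at least 1.1-fold lower number from compound 2 to compound 4 (0.05 log units; that floor lies within the scatter); neither floor shows a change beyond the scatter. Replacing the pent-2-en-1-yl chain with butyl gives a 1.6-fold higher number from compound 3 to compound 4 (0.21 log units; within the scatter), so at this position this change does not move the read-out beyond the scatter. The series stays close to a limit: the limit of > 100000 nM in this assay, at which 2 of the 4 values shown sit.

The compounds shown leave open whether an amine or a carboxylic acid at the end of this chain would give a reading clear of the scatter.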